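Swapping the trichlorophenyl sulfonate ester for 3-fluorophenyl

The compounds below may be only part of what the source reports. "The series", "measured", "known", "first", "only" and "open" are said of these compounds alone.

Compound 1 `CCN1CCN(c2ccc(S(=O)(=O)Oc3cccc(F)c3)cc2)C1=O`: > 100000 nM (a limit)
Compound 2 `CCCN1CCN(c2ccc(S(=O)(=O)Oc3ccc(C)cc3C)cc2)C1=O`: 26000 nM
Compound 3 `CCCN1CCN(c2ccc(S(=O)(=O)Oc3cc(Cl)c(Cl)cc3Cl)cc2)C1=O`: 19000 nM
Compound 4 `CCCN1CCN(c2ccc(S(=O)(=O)Oc3cccc(F)c3)cc2)C1=O`: not yet measured

These compounds were tested in a functional assay on HT-29 cells (Homo sapiens) for antiproliferative activity, read by sulforhodamine B assay, with a stated time of 48 h; on this read-out higher numbers stand for weaker inhibition and lower numbers for stronger inhibition. There, compound 3 gives 19000 nM and compound 2 gives 26000 nM. Within the data shown here, these are the only two numbers available, and they lie within the scatter of each other: a 1.4-fold lower number from compound 2 to compound 3 (0.14 log units; within the scatter). Compound 1 reports only a limit, (the limit of > 100000 nM in this assay, at which 1 of the 3 values shown sits).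

The next change is 3-fluorophenyl in place of 2,4,5-trichlorophenyl on an oxygen. Among the measured compounds shown here, the one measured step on that oxygen, a 1.4-fold lower number from compound 2 to compound 3 (0.14 log units; within the scatter), gives no sign of a large effect from such an exchange. Compound 1 also carries 3-fluorophenyl on an oxygen, though it is not identical to compound 4 elsewhere. The result of compound 1 is a limit, > 100000 nM. That limit tilts the expectation towards a higher number in this assay. The expected step is a 2.4-fold higher number from compound 3 to compound 4 (0.37 log units; beyond the scatter), a modest one. For compound 4 the estimated value is 45000 nM, with an expected range from 19000 nM to 100000 nM.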

Compound 4, half-maximal inhibitory concentration: 18000 nM
For compound 4 the middle estimate is 2.5-fold (0.40 log units) above the measured one; measured number outside the range, below it.
By their numbers in this assay, from the lowest: compounds 4, 3 and 2 (each within the scatter of the next). At a limit, above all of these: compound 1.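

In this assay, 3-fluorophenyl and 2,4,5-trichlorophenyl on the oxygen bound to the sulfonyl sulfur cannot be told apart, with a 1.1-fold lower number from compound 3 to compound 4 (0.02 log units; within the scatter), and the same holds against 2,4-dimethylphenyl, with a 1.4-fold lower number from compound 2 to compound 4 (0.16 log units; within the scatter). Among these compounds, with 3-fluorophenyl held fixed, the one change that shows a step beyond the scatter lies elsewhere: methyl in place of hydrogen on a saturated chain carbon, two bonds along the chain from an amide-type nitrogen in a ring, gives an at least 5.5-fold lower number from compound 1 to compound 4 (0.74 log units; beyond the scatter). Compound 1 stands only as a limit, not as a number: the limit of > 100000 nM in this assay, at which 1 of the 4 values shown sits.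

From the compounds shown here alone, the full size of that chain step remains unknown, and so does whether a still longer chain would continue it. Going by these compounds, it is also open whether an amine or a carboxylic acid on the phenyl group at this oxygen would give a number beyond the scatter.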